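A methoxyphenyl replaces the trifluoromethylphenyl group

The source may hold more compounds than are shown below. What is called first, only, known or untested is meant among the compounds shown, and "the series" means these compounds.

Compound 2 `COC(OC)C1=C(C(=O)OC/C=C/c2ccc(C(F)(F)F)cc2)C(c2cccc(Cl)c2)C(C(=O)O)=C(C)N1` stands highest of the two compounds measured in an assay on thoracic aorta for inhibition of Voltage-gated L-type calcium channel (Rattus norvegicus); a higher number here means a weaker inhibitor, a lower number a stronger inhibitor: compound 2 gives 3200 nM, whereas compound 1 `COC(OC)C1=C(C(=O)OC/C=C/c2ccccc2Cl)C(c2cccc(Cl)c2)C(C(=O)O)=C(C)N1` gives 700 nM. The two differ only in the aryl group on the double-bonded chain carbon bound to a double-bonded chain carbon, and that change gave a 4.6-fold higher number from compound 1 to compound 2 (0.66 log units; beyond the scatter). Compound 3 `COc1cccc(/C=C/COC(=O)C2=C(C(OC)OC)NC(C)=C(C(=O)O)C2c2cccc(Cl)c2)c1` alters the same position once more: 3-methoxyphenyl in place of 4-(trifluoromethyl)phenyl on a double-bonded chain carbon bound to a double-bonded chain carbon. Among the compounds with values here, the single measured step, from compound 1 to compound 2, is the only one that bears on this change, and it shows that swapping the aryl group at this position moved the number by a modest amount. Within the data shown here, no measured pair contains a 3-methoxyphenyl, so the direction for compound 3 is uncertain. Compound 3 is expected to fall between the two measured numbers, a step of a 2.1-fold lower number from compound 2 to compound 3 (0.33 log units; beyond the scatter). Compound 3 is therefore estimated at 1500 nM, within a range from 500 nM to 4500 nM.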

Compound 3, half-maximal inhibitory concentration: 4400 nM
Beside the measured number, compound 3's estimate is 2.9-fold (0.47 log units) below it; the range from low to high includes it.
By their numbers in this assay, from the lowest: compound 1; then compounds 2 and 3 (each within the scatter of the next).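

In this assay, a methoxy-bearing aryl group at this position does not separate from the trifluoromethyl-bearing one, with a 1.4-fold higher number from compound 2 to compound 3 (0.14 log units; within the scatter) as the step, so these two different groups give numbers that cannot be told apart. The 2-chlorophenyl group does stand apart from the new group as well, with a 6.3-fold higher number from compound 1 to compound 3 (0.80 log units; beyond the scatter) as the step, which makes compound 1 the strongest inhibitor of the three and shows that its edge over compound 2 is not limited to the trifluoromethyl group. No measurement shown offers a reason for this pattern.

Each aryl group here differs from the others in both its substituent and that substituent's place on the ring, so the two effects cannot be separated. Going by these compounds, it remains open whether a 2-methoxyphenyl or an unsubstituted phenyl on the same chain would side with compound 1 or with compound 2 and compound 3.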